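This account rests on a few compounds, and the source may have more. Where it says the series, first, only, none or still open, it means among the compounds named here.

Compound 1 `CCOC(=O)c1cnn(-c2nc(-c3ccccc3Cl)c(C#N)c(=O)n2C)c1N`: 93 ug/mL
Compound 2 `CCOC(=O)c1cnn(-c2nc(-c3ccccc3F)c(C#N)c(=O)n2C)c1N`: 87 ug/mL
Compound 3 `CCOC(=O)c1cnn(-c2nc(-c3cccc(O)c3O)c(C#N)c(=O)n2C)c1N`: 58 ug/mL

All three compounds share one core and differ only in the aromatic group attached to it. In a functional assay, with a stated time of 150 min (a lower number here means a stronger inhibitor, a higher number a weaker inhibitor), compound 3 has the lowest of the three numbers, but its steps from the others, a 1.6-fold lower number from compound 1 to compound 3 (0.21 log units; within the scatter) and a 1.5-fold lower number from compound 2 to compound 3 (0.18 log units; within the scatter), both lie within the scatter, so no real order can be read among them; the step of a 1.1-fold lower number from compound 1 to compound 2 (0.03 log units; within the scatter) is within the scatter as well.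

Compound 4 `CCOC(=O)c1cnn(-c2nc(-c3ccc(N(C)C)cc3)c(C#N)c(=O)n2C)c1N` has not yet been measured in this assay. It differs from compound 3 in one place: 4-(dimethylamino)phenyl in place of 2,3-dihydroxyphenyl on an aromatic carbon. The measured steps that bear on this change are the two that also exchange the aromatic group on that carbon, and both were within the scatter, as was the exchange of halogens. Going by the values given here, three different aromatic groups on that carbon thus gave numbers within scatter of one another, and no measured compound carries the 4-(dimethylamino)phenyl group. The step expected is therefore a 1.4-fold higher number from compound 3 to compound 4 (0.14 log units; within the scatter), nothing beyond the scatter. Compound 4 is estimated at 80 ug/mL, with a range from 40 ug/mL to 160 ug/mL.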

Compound 4, half-maximal inhibitory concentration: 115 ug/mL
The estimate for compound 4 lay 1.4-fold (0.16 log units) below the measured number, within the range that was stated.
By their numbers in this assay, from the lowest: compounds 3, 2, 1 and 4 (each within the scatter of the next).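

In this assay, a fourth aromatic group on this carbon, 4-(dimethylamino)phenyl, again stays within the scatter of the others: a 2.0-fold higher number from compound 3 to compound 4 (0.30 log units; within the scatter), a 1.3-fold higher number from compound 2 to compound 4 (0.12 log units; within the scatter) and a 1.2-fold higher number from compound 1 to compound 4 (0.09 log units; within the scatter). Going by these compounds alone, the first of these steps is the widest so far, yet it is still no real change, even though it trades 2,3-dihydroxyphenyl, which has hydrogen-bond donors, for a group with none. The position therefore now shows the same picture with a nitrogen-bearing group placed opposite the ring nitrogen's neighbouring substituents as with halogens or hydroxyl groups: none of the four compounds separates from the others.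

From the compounds shown here alone, whether a carboxylic acid, a primary amine or a longer alkyl chain on this carbon would move the number beyond the scatter remains open. Nothing available explains why these groups give numbers so alike.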